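This account rests on a few compounds, and the source may have more. Where it says the series, first, only, none or still open, it means among the compounds named here.

Compound 1 `O=C(c1ccccc1)N1CCC(C(=O)N2N=CCC2c2ccccc2)CC1` gives 0.0833 h in an ADME assay on microsomes (Rattus norvegicus) for metabolic stability; on this read-out higher numbers stand for a longer-lived compound and lower numbers for a shorter-lived compound. Compound 3 `CC(C)(C)C(=O)N1N=CCC1c1ccc(Cl)cc1` gives 0.145 h in this assay. Compound 2 `O=C(c1cn[nH]c1)N1CCC(C(=O)N2N=CCC2c2ccccc2)CC1` reads > 2.75 h, which is a limit of the assay and not a number.

The next change leads to compound 4 `O=C(c1cc[nH]n1)N1CCC(C(=O)N2N=CCC2c2ccccc2)CC1`: 1H-pyrazol-3-yl in place of 1H-pyrazol-4-yl on a carbonyl carbon, with 1H-pyrazol-3-yl in place of 1H-pyrazol-4-yl on a carbonyl carbon. Going by the values given here, only one measured step bears on it, an at least 33-fold higher number from compound 1 to compound 2 (1.51 log units; beyond the scatter), which is large and beyond the scatter. That step replaced phenyl on the same carbonyl carbon, whereas here a five-membered aromatic ring with 2 hetero atoms leaves and another enters. The evidence therefore offers no direct measure of this swap, and a much smaller shift than the one from phenyl is expected, with no clear direction.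

The expected change is an at least 1.2-fold lower number from compound 2 to compound 4 (0.09 log units; that floor lies within the scatter), which would lie within the scatter. On the strength of the step to compound 2 an at least 33-fold higher number from compound 1 to compound 2 (1.51 log units; beyond the scatter), the half-life should stay long. Compound 4 is estimated at 2.2 h, with an expected range from 0.7 h to 5 h.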

Compound 4, half-life: 0.317 h
Estimate against measurement, compound 4: 6.9-fold (0.84 log units) above, and the stated range ends above it.
By their numbers in this assay, from the lowest: compounds 1 and 3 (each within the scatter of the next); then compound 4. At a limit, above all of these: compound 2.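

On the carbonyl carbon whose other neighbour is an amide-type nitrogen in a ring, a pyrazole alone does not settle the half-life: the attachment of the ring counts, since with the same atoms joined differently the change gives an at least 8.6-fold lower number from compound 2 to compound 4 (0.93 log units; beyond the scatter). Going by these compounds alone, compound 2 stands at a limit of the assay and not at a number, so the size of this step is only a floor: the limit of > 2.75 h in this assay, at which 1 of the 4 values shown sits. Against phenyl, 1H-pyrazol-3-yl still gives a 3.8-fold higher number from compound 1 to compound 4 (0.58 log units; beyond the scatter), which is a real gain but a smaller floor-free reading than the one compound 2 allows.

Going by these compounds, the true position of compound 2, and with it the full gap to compound 4, stays open. Also open, on these data alone, is how a methyl-substituted pyrazole or an imidazole on the same carbonyl carbon would read in this assay.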